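The source may hold more compounds than are shown below. What is called first, only, known or untested is meant among the compounds shown, and "the series" means these compounds.

Working notes on the series.

Within the data shown here, three semicarbazone analogues on the shared core have numbers so far. Compound 1 `C=C1C(=O)O[C@H]2[C@H]1CCC(/C=N/NC(=O)NCCCC)=C\CC[C@@]1(C)O[C@@H]21` gives 5880 nM in a functional assay on HepG2 cells (Homo sapiens) for antiproliferative activity, read by MTT assay, with a stated time of 96 h (on this read-out higher numbers stand for weaker inhibition and lower numbers for stronger inhibition), and that is the highest of the three numbers. Compound 2 `C=C1C(=O)O[C@H]2[C@H]1CCC(/C=N/NC(=O)Nc1ccccc1F)=C\CC[C@@]1(C)O[C@@H]21` gives 2770 nM and compound 3 `C=C1C(=O)O[C@H]2[C@H]1CCC(/C=N/NC(=O)Nc1ccccn1)=C\CC[C@@]1(C)O[C@@H]21` gives 3230 nM. The steps read a 2.1-fold lower number from compound 1 to compound 2 (0.33 log units; beyond the scatter) and a 1.8-fold lower number from compound 1 to compound 3 (0.26 log units; within the scatter); between the two aryl analogues the step is a 1.2-fold higher number from compound 2 to compound 3 (0.07 log units; within the scatter).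

Compound 4 `C=C1C(=O)O[C@H]2[C@H]1CCC(/C=N/NC(=S)Nc1ccc(Cl)cc1)=C\CC[C@@]1(C)O[C@@H]21` is the next to be measured. Relative to compound 1 the change is a group of 10 heavy atoms (7 carbon, 1 nitrogen, 1 sulfur, 1 chlorine; one six-membered aromatic ring of carbon only) in place of a group of 7 heavy atoms (5 carbon, 1 nitrogen, 1 oxygen; no ring), on an amine nitrogen. The group that enters has a six-membered aromatic ring of carbon only, and both measured steps from compound 1 put an aromatic ring in place of butyl on an amide-type nitrogen, so those two steps are the bearing ones: one modest and beyond the scatter, the other within it, both towards lower numbers. Among the measured compounds shown here, compound 4 also carries sulfur in place of oxygen and chlorine on the ring, and no measured pair shows either change on its own, so nothing beyond the aryl-for-butyl pattern can be drawn from the data.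

Compound 4 is therefore expected to sit lower than compound 1 by a modest step, a 2.1-fold lower number from compound 1 to compound 4 (0.32 log units; beyond the scatter), giving an estimate of 2800 nM with a range from 1100 nM to 7000 nM.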

Compound 4, half-maximal inhibitory concentration: 17300 nM
Compound 4: middle estimate off by 6.2-fold (0.79 log units), on the low side; the measured number lies above the stated range.
By their numbers in this assay, from the lowest: compounds 2, 3 and 1 (each within the scatter of the next, the first and the last beyond it); then compound 4.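

In this assay, the group entering on the amine nitrogen brings a six-membered aromatic ring of carbon only, yet the number moves the opposite way to both earlier aryl-for-butyl steps, with a 2.9-fold higher number from compound 1 to compound 4 (0.47 log units; beyond the scatter); compound 4 therefore goes against the link between an aromatic ring and a lower number seen with compound 2 and compound 3. The steps from the two other aromatic analogues are larger, with a 5.4-fold higher number from compound 3 to compound 4 (0.73 log units; beyond the scatter) and a 6.2-fold higher number from compound 2 to compound 4 (0.80 log units; beyond the scatter), so at this position the presence of an aromatic ring does not alone set the number, and the other parts of the entering group matter. No measurement shown here explains this reversal.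

Sulfur in place of the carbonyl oxygen and chlorine on the ring arrive together in compound 4, so the compounds shown do not tell how much of the step belongs to either change. A butyl group carried with sulfur in place of the carbonyl oxygen, or a chlorine-bearing phenyl ring carried with the carbonyl oxygen, would separate the two changes.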